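The source may hold more compounds than are shown below. What is called first, only, known or untested is meant among the compounds shown, and "the series" means these compounds.

Measured so far in an assay on isolated protein for inhibition of Amine oxidase [flavin-containing] B (Homo sapiens), read by fluorescence and Amplex Red, with stated times of 15 min and 20 min; on this read-out lower numbers stand for stronger inhibition and higher numbers for weaker inhibition:
compound 1 `Cc1ccc(/C=N/c2ccc(OCc3ccccc3)cc2)c(O)c1` gives 24400 nM
compound 2 `Oc1ccc(/C=N/c2ccc(OCc3ccccc3)cc2)c(O)c1O` gives 1730 nM

Compound 1 stands at the highest number of the two. Within the data shown here, the gap to compound 2 lies beyond the scatter, but no step between them is drawn; the two values show only that compound 1 is the weaker of the pair in this assay.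

Compound 3 `Oc1ccc(F)cc1/C=N/c1ccc(OCc2ccccc2)cc1` is not yet measured. It differs from compound 1 by 5-fluoro-2-hydroxyphenyl in place of 2-hydroxy-4-methylphenyl on a carbon with a double bond to nitrogen. Among the measured compounds shown here, no matched step of this kind is on record, so the expected step of a 1.6-fold lower number from compound 1 to compound 3 (0.21 log units; within the scatter) in this assay is small, with no confident direction beyond the scatter. The estimate for compound 3 is 15000 nM, within 4000 nM to 50000 nM.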

Compound 3, half-maximal inhibitory concentration: 15300 nM
Estimate against measurement, compound 3: 1.0-fold (0.01 log units) below, within the range that was stated.
By their numbers in this assay, from the lowest: compound 2; then compounds 3 and 1 (each within the scatter of the next).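

In this assay, among these compounds, the only matched step, 5-fluoro-2-hydroxyphenyl in place of 2-hydroxy-4-methylphenyl on a carbon with a double bond to nitrogen, gives a 1.6-fold lower number from compound 1 to compound 3 (0.20 log units; within the scatter) and so does not separate the two compounds. At this place, the assay does not distinguish these two groups. Nothing on hand bears on why they read alike.

Still open, as far as these compounds go, is whether a methoxy group, an amine or a carboxylic acid on this ring would move the number beyond the scatter. Among the compounds shown here, no single-place step yet connects compound 2 to compound 1 or compound 3.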